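This account rests on a few compounds, and the source may have more. Where it says the series, first, only, none or still open, it means among the compounds named here.

Measured so far in an assay on isolated protein for inhibition of Gonadotropin-releasing hormone receptor (Homo sapiens); a higher number here means a weaker inhibitor, a lower number a stronger inhibitor:
- compound 1 `CCSc1nc2cc(S(=O)(=O)NCc3ccc([N+](=O)[O-])cc3)ccc2n1Cc1ccccc1`: 1100 nM
- compound 2 `CCSc1nc2cc(S(=O)(=O)NCc3ccc(Cl)cc3)ccc2n1Cc1ccccc1`: 280 nM

Going by the values given here, compound 2 holds the lowest of the two numbers in this assay; the only measured step, a 3.9-fold lower number from compound 1 to compound 2 (0.59 log units; beyond the scatter), separates it from compound 1, the sole neighbour. Compound 3 `CCSc1nc2cc(S(=O)(=O)NCc3ccc(F)cc3)ccc2n1Cc1ccccc1` is the next compound in line and differs from compound 2 by fluoro in place of chloro on an aromatic carbon. Among the compounds with values here, no measured step exchanges one halogen for another; the one step in hand, a 3.9-fold lower number from compound 1 to compound 2 (0.59 log units; beyond the scatter), concerns a different substituent at the same aromatic carbon and so gives only indirect guidance. With nothing measured for a halogen-to-halogen swap, the expected step for compound 3 in this assay is a small one, a 1.4-fold higher number from compound 2 to compound 3 (0.15 log units; within the scatter), not beyond the scatter, its direction undetermined. Compound 3 is therefore estimated at 400 nM, with a range from 150 nM to 1200 nM in this assay.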

Compound 3, half-maximal inhibitory concentration: 250 nM
The estimate for compound 3 lay 1.6-fold (0.20 log units) above the measured number; the range from low to high includes it.
By their numbers in this assay, from the lowest: compounds 3 and 2 (each within the scatter of the next); then compound 1.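

In this assay, fluoro in place of chloro on this aromatic carbon, para to a large group, gives a 1.1-fold lower number from compound 2 to compound 3 (0.05 log units; within the scatter) and so does not separate the two halogens, which the earlier pair could not show. Fluoro in place of nitro gives a 4.4-fold lower number from compound 1 to compound 3 (0.64 log units; beyond the scatter) at the same carbon, so in these compounds the separation beyond the scatter lies between nitro and either halogen, not between the halogens themselves. No measurement in hand accounts for either step.

Going by these compounds, whether a methoxy group, an amine or a carboxylic acid on this carbon would fall with the two halogens or with the nitro compound remains open. Also open, on these data alone, is whether fluoro and chloro would stay within the scatter of each other on other carbons of this ring.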